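The compounds below may be only part of what the source reports. "The series", "measured", "known", "first", "only" and "open" are said of these compounds alone.

Of the compounds shown here, two built on a shared core have so far been measured in a functional assay on CHO cells for agonist activity at adenosine receptor A1 (Homo sapiens), read by fluorescence and ERK phosphorylation, with stated times of 30 min and 1.5 h, tested at 3 uM; a lower number here means a weaker effect, a higher number a stronger effect of the compound at the concentration tested. Compound 1 `Nc1scc(-c2cccc(F)c2)c1C(=O)c1ccc(Cl)cc1` gives 76%, and compound 2 `Nc1scc(-c2ccc(F)cc2)c1C(=O)c1ccc(Cl)cc1` gives 62%. Compound 2 therefore stands lowest of the two numbers, set apart from compound 1 by a number 14 percentage points lower from compound 1 to compound 2 (beyond the scatter), a modest step that came with 4-fluorophenyl in place of 3-fluorophenyl on an aromatic carbon.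

Compound 3 `Nc1scc(-c2ccc([N+](=O)[O-])cc2)c1C(=O)c1ccc(Cl)cc1` is not yet measured. It differs from compound 2 by nitro in place of fluoro on an aromatic carbon; the fluoro leaves and a nitro enters, para to a large group. Among the measured compounds shown here, the one measured step, a number 14 percentage points lower from compound 1 to compound 2 (beyond the scatter), moved a fluoro from one position to another rather than exchanging it for a different group, so it bears on the new step only loosely, though it shows that a change on this ring can shift this assay by a modest amount. Nothing measured here indicates the direction of exchanging fluoro for nitro. A modest step in either direction, or none beyond the scatter, is expected. The estimate for compound 3 is 55%, ranging from 30% to 80%. This estimate corresponds to an expected step of a number 7 percentage points lower from compound 2 to compound 3 (within the scatter).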

Compound 3, a percentage reported as activity, at one concentration (the size of the read-out at that concentration, not a potency): 47%
Estimate against measurement, compound 3: 8 percentage points above; the range from low to high includes it.
By their numbers in this assay, from the lowest: compound 3; then compound 2; then compound 1.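

With the fluoro exchanged rather than moved, this assay shows a number 15 percentage points lower from compound 2 to compound 3 (beyond the scatter) as nitro replaces fluoro para to a large group. The earlier pair showed only that the place of a fluoro on this ring matters to the read-out; this pair shows that, with the place held fixed, the identity of the group matters as well, although compound 3 still gives 47% and so keeps a clear effect at the concentration tested with the larger nitro, which brings in two hydrogen-bond acceptors. Nothing available explains the lower number, and the pair alone cannot tell which difference between the fluoro and the nitro goes with it.

The compounds shown leave open whether the lower number is particular to nitro or would also follow with another group at this place, such as an amine, a carboxylic acid or a longer chain. They also leave open how a nitro would behave on the ring position that carries the fluoro in compound 1, so the two changes on this ring cannot yet be read together.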